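Benzyl carbamate of a selenocyanate aniline: an estimate

A few compounds are considered here, and "the series" means these few. Any claim that something is new, unique, unknown or untested is made for them only; others in the source may bear on it.

Measured compounds:
- Compound 1, `COc1ccc(OC(=O)Nc2ccc([Se]C#N)cc2)cc1`: 48200 nM
- Compound 2, `CCCCOC(=O)Nc1ccc([Se]C#N)cc1`: 20200 nM
- Compound 3, `Cc1ccc(OC(=O)Nc2ccc([Se]C#N)cc2)cc1`: 39900 nM

All three share a selenocyanate-bearing aniline core joined through a carbamate to a variable group. Among the compounds with values here, in a functional assay on MCF7 cells (Homo sapiens) for cytotoxicity, read by MTT assay, with a stated time of 72 h (on this read-out higher numbers stand for weaker inhibition of growth and lower numbers for stronger inhibition of growth), compound 1 gives 48200 nM and compound 3 gives 39900 nM; the one step between them, a 1.2-fold lower number from compound 1 to compound 3 (0.08 log units; within the scatter), lies within the scatter. Compound 2 gives 20200 nM, a lower number than compound 1 beyond the scatter, while compound 2 and compound 3 lie within the scatter of each other.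

The next compound is compound 4, `N#C[Se]c1ccc(NC(=O)OCc2ccccc2)cc1`. It differs from compound 2 by phenyl in place of propyl on a saturated chain carbon bound to an oxygen next to a carbonyl group. Within the data shown here, no measured step touches this kind of change: the only step on record, from compound 1 to compound 3, swaps one small substituent for another on an aromatic carbon and shows nothing beyond the scatter. What the data do show is that the two compounds carrying an aromatic ring on the carbamate oxygen, compound 1 and compound 3, sit at somewhat higher numbers than compound 2. Compound 4 places its aromatic ring one chain carbon away from that oxygen, so a small rise in the number, or none beyond the scatter, is expected.

The step from compound 2 to compound 4 is estimated as a 1.3-fold higher number from compound 2 to compound 4 (0.11 log units; within the scatter). Compound 4 is therefore expected to give 26000 nM, with a likely range from 12000 nM to 55000 nM.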

Compound 4, concentration for total growth inhibition: 38800 nM
Compound 4: middle estimate off by 1.5-fold (0.17 log units), on the low side; the measured number falls inside the stated range.
By their numbers in this assay, from the lowest: compounds 2, 4, 3 and 1 (each within the scatter of the next, the first and the last beyond it).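

Within the data shown here, this is the first measured change at this place, on a saturated chain carbon bound to an oxygen next to a carbonyl group, and it is a large change in shape: propyl, with 3 heavy atoms and no ring, gives way to phenyl, with 6 heavy atoms in one six-membered aromatic ring. Yet in this assay the result is a 1.9-fold higher number from compound 2 to compound 4 (0.28 log units; within the scatter), so this read-out does not separate the two groups, and a chain and a ring can both stand at this place without a difference beyond the usual scatter of repeated measurements. No measurement at hand accounts for the size of this step.

As far as these compounds go, only propyl and phenyl have been compared at this place, so the effect of a longer chain, an amine or a carboxylic acid there remains unknown. From the compounds shown here alone, it is also open whether a methyl or methoxy group on the phenyl ring of compound 4 would shift the number beyond the scatter, or leave it within.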